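From compound 2 to compound 3: a piperidin-1-yl swap

The source may report more compounds than this note shows. Statements on the series, on what has been measured and on what is new or still open speak of the compounds shown alone.

Compound 1 `Cc1cc(=O)c2c(O)cc(O)c([C@H]3CCN(C)C[C@H]3OC(=O)c3ccco3)c2o1` gives 33%
Compound 2 `Cc1cc(=O)c2c(O)c(CN(C)CC(=O)O)c(O)c([C@H]3CCN(C)C[C@H]3O)c2o1` gives 18%

Both numbers come from a functional assay on Caco-2 cells (Homo sapiens) for inhibition, read by MTT assay, with a stated time of 48 h, tested at 10 uM (a lower number here means less inhibition of growth, a higher number more inhibition of growth at the concentration tested), and compound 2 (18%) stands lowest of the two, with compound 1 higher by more than the usual scatter.

Compound 3 `Cc1cc(=O)c2c(O)c(CN3CCCCC3)c(O)c([C@H]3CCN(C)C[C@H]3O)c2o1` keeps the rest of compound 2, but piperidin-1-yl takes the place of (carboxymethyl)(methyl)amino on a saturated chain carbon bound to an aromatic carbon (piperidin-1-yl in place of (carboxymethyl)(methyl)amino on a saturated chain carbon bound to an aromatic carbon).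

For the measured compounds named here, no two measured compounds differ in one place only, so the data offer no direct guide to this change. Since compound 2 (18%) holds the lower of the two numbers, a modest rise is expected, and it may stay within the scatter. The expected change is a number 9 percentage points higher from compound 2 to compound 3 (within the scatter) and it is only a rough estimate. For compound 3 the estimate in this assay is 27% (expected range 10% to 48%).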

Compound 3, percent growth inhibition at one concentration: 22%
For compound 3 the middle estimate is 5 percentage points above the measured one; the range from low to high includes it.
By their numbers in this assay, from the lowest: compounds 2 and 3 (each within the scatter of the next); then compound 1.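

In this assay, replacing (carboxymethyl)(methyl)amino with piperidin-1-yl on a saturated chain carbon bound to an aromatic carbon gives a number 4 percentage points higher from compound 2 to compound 3 (within the scatter), so the two compounds cannot be told apart. This place therefore accepts a ring with no hydrogen-bond donor as well as an open chain ending in a carboxylic acid, with the read-out staying within the scatter, at least for this one pair. Nothing available explains why the swap leaves the reading unchanged.

On these data alone, whether a morpholin-4-yl ring or a small dimethylamino group on the same carbon would read alike remains open. Compound 1 differs from both compounds in more than one place, so it gives no reading on this position.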